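From isopropyl to cyclopentyl on the sulfur

The source may hold more compounds than are shown below. What is called first, only, known or untested is meant among the compounds shown, and "the series" means these compounds.

In a functional assay on MT4 cells (Homo sapiens) for cytotoxicity (on this read-out higher numbers stand for lower toxicity in this test and lower numbers for higher toxicity in this test), compound 2 (`CC(C)Sc1nc(O)cc(C(C)c2cccc3ccccc23)n1`) gives 119000 nM. Compound 1 (`CCC(C)Sc1nc(O)cc(C(C)c2ccccc2)n1`) gives 200000 nM, which lies within the usual scatter of the value for compound 2, so the two share the high end of the three numbers measured. Compound 3 (`CCC(c1cc(O)nc(SC(C)C)n1)c1cccc2ccccc12`) gives 16900 nM, well apart from that pair.

Compound 4 (`CC(c1cc(O)nc(SC2CCCC2)n1)c1cccc2ccccc12`) differs from compound 2 in one place, with cyclopentyl in place of isopropyl on a sulfur. For the measured compounds named here, no measured step changes the group on the sulfur, so the data offer no direct guide to this change. The nearest evidence is the step of a 7.0-fold lower number from compound 2 to compound 3 (0.85 log units; beyond the scatter), a modest change that came with a methyl in place of hydrogen on a saturated chain carbon, elsewhere in the molecule. That step also adds carbon, and it is the only reason to lean towards a lower number here, so the same direction is expected, with a size no larger and with real uncertainty. The expected step is a 2.2-fold lower number from compound 2 to compound 4 (0.34 log units; beyond the scatter). For compound 4 the estimated value is 55000 nM, with an expected range from 15000 nM to 170000 nM.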

Compound 4, half-maximal cytotoxic concentration: 93000 nM
Compound 4: the middle estimate sits 1.7-fold (0.23 log units) below what was measured; low and high end bracket the measured number.
By their numbers in this assay, from the lowest: compound 3; then compounds 4, 2 and 1 (each within the scatter of the next, the first and the last beyond it).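

In this assay, for the compounds shown here, the first direct reading of a change on the sulfur is a 1.3-fold lower number from compound 2 to compound 4 (0.11 log units; within the scatter), so compound 2 and compound 4 cannot be told apart on this read-out, even though one five-membered non-aromatic ring of carbon only takes the place of isopropyl. At this position, then, the added carbon does not bring a step beyond the scatter, unlike the methyl on the saturated chain carbon, which gave a 7.0-fold lower number from compound 2 to compound 3 (0.85 log units; beyond the scatter). There is no measurement here that would account for this result, and the reading goes no further than the numbers themselves.

From the compounds shown here alone, both groups seen on this sulfur in the comparison contain carbon only, so it remains open what an amine, a carboxylic acid or a longer chain such as n-hexyl would do at this position. Going by these compounds alone, it is also open whether cyclopentyl in place of isopropyl on a sulfur would give a similar result in the setting of compound 3, the one compound whose number stands beyond the scatter from compound 2.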